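The compounds below may be only part of what the source reports. "The series", "measured", "known", "first", "only" and "open" are said of these compounds alone.

Measured so far in an ADME assay for pharmacokinetics; on this read-out lower numbers stand for a shorter-lived compound and higher numbers for a longer-lived compound:
compound 1 `CCO/C(O)=C1\C(COCCn2cc(C(N)=O)nn2)=NC(C)=C(C(=O)OC)C1c1cccc(Cl)c1Cl` — 0.333 h
compound 2 `CCO/C(O)=C1\C(COCCn2ccnn2)=NC(C)=C(C(=O)OC)C1c1cccc(Cl)c1Cl` — 0.5 h
compound 3 `CCO/C(O)=C1\C(COCCN2CC(=O)N(C)C2=O)=NC(C)=C(C(=O)OC)C1c1cccc(Cl)c1Cl` — 0.167 h

Compound 1 stands second highest of the three in this assay. Its nearest neighbour is compound 2, with a 1.5-fold higher number from compound 1 to compound 2 (0.18 log units; within the scatter), and its furthest is compound 3, with a 2.0-fold lower number from compound 1 to compound 3 (0.30 log units; within the scatter); neither of these steps passes the scatter. Among the compounds with values here, the only step that does is a 3.0-fold lower number from compound 2 to compound 3 (0.48 log units; beyond the scatter).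

Compound 4 `CCO/C(O)=C1\C(COCCN2CC(=O)NC2=O)=NC(C)=C(C(=O)OC)C1c1cccc(Cl)c1Cl` differs from compound 1 by 2,4-dioxoimidazolidin-1-yl in place of 4-carbamoyl-1H-1,2,3-triazol-1-yl on a saturated chain carbon, two bonds along the chain from an oxygen on a saturated carbon. The entering group, 2,4-dioxoimidazolidin-1-yl, is the ring that compound 3 carries as 3-methyl-2,4-dioxoimidazolidin-1-yl, so the two steps into compound 3 bear on this change: a 2.0-fold lower number from compound 1 to compound 3 (0.30 log units; within the scatter) lay within the scatter, and a 3.0-fold lower number from compound 2 to compound 3 (0.48 log units; beyond the scatter) was modest but beyond it. On this basis the step from compound 1 to compound 4 is expected to be small and, if anything, downward: a 1.7-fold lower number from compound 1 to compound 4 (0.22 log units; within the scatter). Compound 4 is therefore estimated at 0.2 h, with a range from 0.1 h to 0.4 h.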

Compound 4, half-life: 0.5 h
Compound 4: the middle estimate sits 2.5-fold (0.40 log units) below what was measured; the measured number lies above the stated range.
By their numbers in this assay, from the lowest: compounds 3, 1, 2 and 4 (each within the scatter of the next, the first and the last beyond it).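

In this assay, hydrogen in place of methyl on an amide-type nitrogen in a ring gives a 3.0-fold higher number from compound 3 to compound 4 (0.48 log units; beyond the scatter), so the low number of compound 3 belongs to the methylated ring and not to the 2,4-dioxoimidazolidin-1-yl ring as such. Without that methyl, the ring exchanges at this saturated chain carbon read a 1.5-fold higher number from compound 1 to compound 4 (0.18 log units; within the scatter) and no change at the digits printed from compound 2 to compound 4 (within the scatter), leaving the unmethylated ring and both triazolyl groups undistinguished here, although the step from compound 1 to compound 3 also stays within the scatter. No measurement is available to account for the methyl step.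

As far as these compounds go, whether ethyl or a longer chain on that nitrogen would behave as methyl does remains open. Also open, from the compounds shown here alone, is how a carboxylic acid or an amine in place of the carbamoyl on the triazole would read.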